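This account rests on a few compounds, and the source may have more. Where it says the series, first, only, none or still open, it means among the compounds named here.

Measured so far in a functional assay on BXPC-3 cells (Homo sapiens) for inhibition, read by MTT assay, with a stated time of 7 days; on this read-out lower numbers stand for stronger inhibition and higher numbers for weaker inhibition:
- compound 1 `CCOC(=O)[C@@H]1CCCN(S(=O)(=O)c2ccc(S(=O)(=O)N3CCOCC3)cc2)C1` gives 23400 nM
- compound 2 `CCN(CC)S(=O)(=O)c1ccc(S(=O)(=O)N2CCC[C@@H](C(=O)N3CCC(c4nc(C(C)C)no4)CC3)C2)cc1` gives 300 nM

Compound 1 stands at the highest of the two numbers in this assay; compound 2 sits far lower, and the gap lies beyond the scatter. Going by the values given here, no step between measured compounds that differ in one place is available, so the change to compound 3 `CCOC(=O)[C@@H]1CCCN(S(=O)(=O)c2ccc(S(=N)(=O)N(CC)CC)cc2)C1` has no direct precedent. It is a group of 8 heavy atoms (4 carbon, 2 nitrogen, 1 oxygen, 1 sulfur; no ring) in place of a group of 9 heavy atoms (4 carbon, 1 nitrogen, 3 oxygen, 1 sulfur; one six-membered non-aromatic ring with 2 hetero atoms), on an aromatic carbon. Given compound 1 at 23400 nM and no matched step, only a modest move, if any beyond the scatter, is expected, and the step from compound 1 to compound 3 is estimated at a 1.6-fold lower number from compound 1 to compound 3 (0.19 log units; within the scatter). Compound 3 is expected near 15000 nM, within 5000 nM to 45000 nM.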

Compound 3, half-maximal inhibitory concentration: 3600 nM
Estimate against measurement, compound 3: 4.2-fold (0.62 log units) above, outside the stated range (below it).
By their numbers in this assay, from the lowest: compound 2; then compound 3; then compound 1.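

In this assay, going by these compounds alone, the open-chain group of compound 3, in place of the (morpholin-4-yl)sulfonyl of compound 1, gives a 6.5-fold lower number from compound 1 to compound 3 (0.81 log units; beyond the scatter) and is the first step read on this aromatic carbon. The position, para to a large group, therefore responds to this change, and the six-membered ring of compound 1 is not needed for activity here. The step removes that ring and adds a hydrogen-bond donor together, and no measurement shown separates the two or accounts for the step.

Which of the two changes carries the step stays open. So does how a piperidin-1-ylsulfonyl group, which keeps a ring but adds no donor, would read at this position.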